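The compounds below may be only part of what the source reports. "The series", "measured", "known", "first", "only" and "open" are said of these compounds alone.

Of the compounds shown here, three of a shared core type have been measured in an assay on A10 cells for binding affinity to Endothelin-1 receptor (Rattus norvegicus); on this read-out higher numbers stand for weaker inhibition and lower numbers for stronger inhibition. Compound 1 `O=C(O)CCC(Oc1cccc(OCc2ccccc2)c1)c1ccccc1` gives 2000 nM. Compound 2 `O=C(O)CC/C(=C/c1cccc(OCc2ccccc2)c1)c1ccccc1` gives 5300 nM. Compound 3 `Cc1ccccc1/C(=C\c1cc(OCc2ccsc2)ccc1Br)C(=O)O` gives 3000 nM. The number for compound 3 sits close to that of compound 1, and its difference from that of compound 2 is also within the usual scatter, so the three values cannot be put in any order.

Compound 4 `Cc1ccccc1/C(=C\c1cc(OCc2ccsc2)ccc1C#N)C(=O)O` has not been measured. It differs from compound 3 in one place: cyano in place of bromo on an aromatic carbon. Among the compounds with values here, no pair of measured compounds shows this exchange, so there is no direct step in this assay to lean on.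

Given that the measured compounds all fall within scatter of one another, the step from compound 3 to compound 4 is expected to be small, a 1.2-fold higher number from compound 3 to compound 4 (0.07 log units; within the scatter), with no clear direction beyond the scatter. Compound 4 is therefore estimated to give 3500 nM in this assay, with a range from 1200 nM to 10000 nM.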

Compound 4, half-maximal inhibitory concentration: 300 nM
Estimate against measurement, compound 4: 12-fold (1.07 log units) above, outside the stated range (below it).
By their numbers in this assay, from the lowest: compound 4; then compounds 1, 3 and 2 (each within the scatter of the next, the first and the last beyond it).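

Cyano in place of bromo on the aromatic carbon para to the (thiophen-3-yl)methoxy group gives, in this assay, a 10-fold lower number from compound 3 to compound 4 (1.00 log units; beyond the scatter) as the only step between compounds that differ in one place. The earlier compounds shown here could not be put in any order and gave no sign that this position mattered, whereas this single exchange shows that the read-out responds clearly to the group held there. Nothing measured here bears on why this exchange has such a large effect.

On these data alone, whether the same kind of step would come with other groups at this position, such as a methyl, a methoxy or a carboxylic acid, remains open. Also open, as far as these compounds go, is whether the exchange would carry over if a benzyloxy group replaced the (thiophen-3-yl)methoxy group.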